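Ethoxy in place of trifluoromethoxy on the aromatic ring

The source may hold more compounds than are shown below. What is called first, only, known or untested is meant among the compounds shown, and "the series" means these compounds.

Compound 1 `CSc1ccc2nc(C)cc(OCC(=O)Nc3cc(C)cc(C)c3)c2c1`: a physicochemical assay for lipophilicity, read by HPLC, in phosphate buffer, measured as chromatographic lipophilicity, at pH 7.4 (on this read-out higher numbers stand for higher lipophilicity and lower numbers for lower lipophilicity), 6.42
Compound 2 `Cc1cc(C)cc(NC(=O)COc2cc(C)nc3ccc(Cl)cc23)c1`: 6.38
Compound 3 `Cc1cc(C)cc(NC(=O)COc2cc(C)nc3ccc(OC(F)(F)F)cc23)c1`: 6.79

Compound 3 stands highest of the three numbers in this assay: the step of a number 0.37 log units higher from compound 1 to compound 3 (beyond the scatter) and the step of a number 0.41 log units higher from compound 2 to compound 3 (beyond the scatter) both lie beyond the scatter, whereas a number 0.04 log units lower from compound 1 to compound 2 (within the scatter) does not. Compound 4 `CCOc1ccc2nc(C)cc(OCC(=O)Nc3cc(C)cc(C)c3)c2c1` differs from compound 3 by ethyl in place of trifluoromethyl on an oxygen on an aromatic ring. Among the compounds with values here, no measured pair exchanges these two groups directly; the steps that bear on it are the two into compound 3, each a modest rise when trifluoromethoxy entered. Taking trifluoromethoxy out again is therefore expected to lower the read-out by a step of comparable size, a number 0.54 log units lower from compound 3 to compound 4 (beyond the scatter). Compound 4 is estimated at 6.25, with a range from 5.9 to 6.6.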

Compound 4, distribution coefficient: 5.98
Compound 4: middle estimate off by 0.27 log units, on the high side; measured number inside the range.
By their numbers in this assay, from the lowest: compound 4; then compounds 2 and 1 (each within the scatter of the next); then compound 3.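

In this assay, within the data shown here, ethoxy gives the lowest number of the four on this aromatic carbon, with a number 0.40 log units lower from compound 2 to compound 4 (beyond the scatter) and a number 0.44 log units lower from compound 1 to compound 4 (beyond the scatter) against two groups that the earlier compounds could not separate. The largest step at this position is a number 0.81 log units lower from compound 3 to compound 4 (beyond the scatter) and it joins two groups attached through oxygen, so that attachment alone does not set the number, with chloro and methylsulfanyl lying in the middle. Nothing measured here accounts for these steps.

From the compounds shown here alone, whether a longer chain on the oxygen, such as propoxy, would extend this trend remains open. So does the place of an amine on this aromatic carbon.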